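The compounds below may be only part of what the source reports. "The series", "measured", "known", "first", "only" and "open" are said of these compounds alone.

Compound 1 `COc1ccc(CNc2nc(SC)nc3ccccc23)cc1` is a weak inhibitor of growth: in a functional assay on CCRF-CEM cells (Homo sapiens) for cytotoxicity, read by MTT assay, with a stated time of 72 h (a lower number here means a stronger inhibitor of growth, a higher number a weaker inhibitor of growth), compound 1 gives 93700 nM. Within the data shown here, of the two numbers known so far, compound 1 stands highest, and its nearest neighbour is compound 2 `CSc1nc(NCc2ccccc2)c2ccccc2n1`, which in this assay gives 87900 nM; the step of a 1.1-fold lower number from compound 1 to compound 2 (0.03 log units; within the scatter) stays within the scatter. Compound 3 `CSc1ccc(CNc2nc(SC)nc3ccccc23)cc1` returns only a limit in this assay, namely > 100000 nM. Because one of the three values sits at the limit of > 100000 nM in this assay, at which 1 of the 3 values shown sits, both an at least 1.0-fold higher number from compound 1 to compound 3 (0.02 log units; that floor lies within the scatter) and an at least 1.1-fold higher number from compound 2 to compound 3 (0.05 log units; that floor lies within the scatter) have only a floor, and each floor lies within the scatter. Taken together, the three measured steps show a series in which swapping the group on the benzyl ring between methoxy, hydrogen and methylsulfanyl leaves the read-out essentially unchanged.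

Compound 4 `COc1ccc(CNc2nc([Se]C)nc3ccccc23)cc1` leaves that benzyl ring alone and instead alters the core: a group of 2 heavy atoms (1 carbon, 1 selenium; no ring) in place of a group of 2 heavy atoms (1 carbon, 1 sulfur; no ring), on an aromatic carbon. Among the measured compounds shown here, none of the measured steps touches this position, so they offer no direct guide to the size of the change; what they do show is that every alteration tried so far has stayed within the scatter. On that basis no step beyond the scatter is expected, and the change a 1.0-fold higher number from compound 1 to compound 4 (0.01 log units; within the scatter) is estimated to be flat. Compound 4 is therefore expected to give about 95000 nM in this assay, with a plausible range from 45000 nM to 200000 nM.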

Compound 4, concentration for 50% growth inhibition: > 100000 nM
Compound 4: only a limit was reported (the forecaster's own chance of this, stated with the estimate: 40%); middle value at least 1.0-fold (0.02 log units) away from the limit.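

In this assay compound 4 gives > 100000 nM, which is a limit of the assay and not a number. This is the first change shown on the aromatic carbon between two ring nitrogen atoms, where a group of 1 carbon and 1 selenium replaces methylsulfanyl, and its step is an at least 1.0-fold higher number from compound 1 to compound 4 (0.02 log units; that floor lies within the scatter), so only a floor is known and how far compound 4 truly lies from compound 1 cannot be read. The position therefore gives no sign of a stronger inhibitor of growth with this change, but the result cannot separate a flat step from a larger loss, and a second compound now rests on the same limit: the limit of > 100000 nM in this assay, at which 2 of the 4 values shown sit.

As far as these compounds go, it remains open whether a different group at this position, such as an amine or a longer chain in place of methylsulfanyl, would move the read-out beyond the scatter in either direction. Also open, from the compounds shown here alone, is whether the selenium-containing group would act in the same way alongside the hydrogen of compound 2 or the methylsulfanyl on the benzyl ring of compound 3.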